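Swapping the benzyl substituent in a sulfonamide series

This account rests on a few compounds, and the source may have more. Where it says the series, first, only, none or still open, it means among the compounds named here.

Three compounds sharing a sulfonamide core were tested in a functional assay on A2780 cells (Homo sapiens) for inhibition, read by MTT assay, with a stated time of 72 h; on this read-out higher numbers stand for weaker inhibition of growth and lower numbers for stronger inhibition of growth. Compound 1 `COc1ccc(CNCCCNS(=O)(=O)c2cc(C(F)(F)F)cc(C(F)(F)F)c2)cc1OC` gives 3800 nM in this assay. Compound 2 `O=S(=O)(NCCCNCc1ccccc1)c1cc(C(F)(F)F)cc(C(F)(F)F)c1` gives 4900 nM, and compound 3 `O=S(=O)(NCCCNCc1ccc(Cl)cc1)c1cc(C(F)(F)F)cc(C(F)(F)F)c1` gives 1800 nM. Compound 3 therefore shows the lowest number of the three, separated from compound 1 by a 2.1-fold lower number from compound 1 to compound 3 (0.32 log units; beyond the scatter) and from compound 2 by a 2.7-fold lower number from compound 2 to compound 3 (0.43 log units; beyond the scatter), while the two remaining compounds are close to each other, as seen in a 1.3-fold higher number from compound 1 to compound 2 (0.11 log units; within the scatter).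

Compound 4 `COc1ccccc1CNCCCNS(=O)(=O)c1cc(C(F)(F)F)cc(C(F)(F)F)c1` has not yet been measured. It differs from compound 3 in one place: 2-methoxyphenyl in place of 4-chlorophenyl on a saturated chain carbon bound to an amine nitrogen. For the measured compounds named here, two measured steps bear on this change. The comparison of compound 2 with compound 3 shows what the chloro on the aromatic ring is worth, and the comparison of compound 1 with compound 3 shows that a methoxy-bearing phenyl in that position fared worse than the 4-chlorophenyl. Both point in the same direction, so compound 4 is expected to give a higher number than compound 3, by roughly the size of those steps, meaning an estimated 2.2-fold higher number from compound 3 to compound 4 (0.35 log units; beyond the scatter). On this reasoning compound 4 is estimated at 4000 nM, with a likely range from 1800 nM to 9000 nM.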

Compound 4, concentration for 50% growth inhibition: 1500 nM
Beside the measured number, compound 4's estimate is 2.7-fold (0.43 log units) above it, outside the stated range (below it).
By their numbers in this assay, from the lowest: compounds 4 and 3 (each within the scatter of the next); then compounds 1 and 2 (each within the scatter of the next).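

In this assay, the 2-methoxyphenyl and the 4-chlorophenyl cannot be told apart on this saturated chain carbon bound to an amine nitrogen (a 1.2-fold lower number from compound 3 to compound 4 (0.08 log units; within the scatter)), so among these compounds a chloro is not the only substituent that goes with a lower number than the plain phenyl. The plain phenyl and the 2-methoxyphenyl are separated by a step of their own (a 3.3-fold lower number from compound 2 to compound 4 (0.51 log units; beyond the scatter)), which shows that a methoxy-bearing phenyl here is not in itself tied to a higher number. The 3,4-dimethoxyphenyl and the 2-methoxyphenyl also part ways (a 2.5-fold lower number from compound 1 to compound 4 (0.40 log units; beyond the scatter)): compound 1 stays within the scatter of compound 2, while compound 4 does not, so methoxy-bearing phenyls cannot be treated as one class at this position. Nothing among the data offered accounts for these differences.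

The compounds shown leave open whether a 4-methoxyphenyl would match the 2-methoxyphenyl or the 3,4-dimethoxyphenyl, and whether a 2-chlorophenyl would match the 4-chlorophenyl. They also leave open whether a longer chain would keep these numbers.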